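From 3-amino-4-methoxybenzyl to 3-hydroxy-4-methoxybenzyl

This account rests on a few compounds, and the source may have more. Where it says the series, first, only, none or still open, it means among the compounds named here.

In a functional assay on HCT-116 cells (Homo sapiens) for inhibition, read by CCK-8 assay, with a stated time of 48 h (on this read-out lower numbers stand for stronger inhibition and higher numbers for weaker inhibition), compound 1 `COc1cc(N(Cc2ccc(Cl)cc2)C(=O)CSC(=S)N2CCN(C(=O)OC(C)(C)C)CC2)cc(OC)c1OC` gives 8490 nM, while compound 2 `COc1ccc(CN(C(=O)CSC(=S)N2CCN(C(=O)OC(C)(C)C)CC2)c2cc(OC)c(OC)c(OC)c2)cc1N` gives 352 nM, the lower of the two numbers. Compound 3 `COc1ccc(CN(C(=O)CSC(=S)N2CCN(C(=O)OC(C)(C)C)CC2)c2cc(OC)c(OC)c(OC)c2)cc1O` differs from compound 2 at one place: hydroxy in place of amino on an aromatic carbon. In words, this is hydroxy in place of amino on an aromatic carbon, ortho to a methoxy group. Within the data shown here, only one measured step bears on this change: a 24-fold lower number from compound 1 to compound 2 (1.38 log units; beyond the scatter), large and beyond the scatter, with 3-amino-4-methoxyphenyl in place of 4-chlorophenyl. Among the measured compounds shown here, that step replaced the whole group, so it does not isolate the amino group, and no measured pair tests amino against hydroxy. No direction is therefore favoured, and no step beyond the scatter is expected in this assay, though with real uncertainty. For compound 3 the expected value is 320 nM, with an estimated range of 80 nM to 1500 nM. The estimate means a 1.1-fold lower number from compound 2 to compound 3 (0.04 log units; within the scatter), an expected step.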

Compound 3, half-maximal inhibitory concentration: 128 nM
Compound 3: middle estimate off by 2.5-fold (0.40 log units), on the high side, within the range that was stated.
By their numbers in this assay, from the lowest: compound 3; then compound 2; then compound 1.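

In this assay, amino and hydroxy can now be compared directly on this aromatic carbon, ortho to a methoxy group: the change gives a 2.8-fold lower number from compound 2 to compound 3 (0.44 log units; beyond the scatter), although the heavy-atom, hydrogen-bond donor and acceptor counts printed for the two groups match. The replacement of 4-chlorophenyl also has a second measured case, a 66-fold lower number from compound 1 to compound 3 (1.82 log units; beyond the scatter), so a large step on leaving 4-chlorophenyl is not confined to the amino compound. Nothing available explains why hydroxy and amino differ here.

Open, on these data alone, is how a fluoro, methylamino or acetamido group on this aromatic carbon would read in this assay. Also open, as far as these compounds go, is whether the hydroxy group keeps its standing in this read-out without the neighbouring methoxy group's presence, as in a plain 3-hydroxyphenyl.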